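This account rests on a few compounds, and the source may have more. Where it says the series, first, only, none or still open, it means among the compounds named here.

Among the compounds with values here, in a functional assay on A549 cells (Homo sapiens) for inhibition, read by MTT assay, with a stated time of 72 h (a higher number here means a weaker inhibitor, a lower number a stronger inhibitor), compound 3 `c1ccc(-c2nnc(SCCCN3CCN(c4nc5ccccc5s4)CC3)o2)cc1` gives 257000 nM, the highest number of the three measured so far, which makes it the weakest of them. Compound 1 `Cc1ccc(-c2nnc(SCCCN3CCN(c4nc5ccccc5s4)CC3)o2)cc1` gives 53900 nM and compound 2 `CC(C)(C)Oc1ccc(-c2nnc(SCCCN3CCN(c4nc5ccccc5s4)CC3)o2)cc1` gives 71600 nM, and these two are not told apart: a 1.3-fold higher number from compound 1 to compound 2 (0.12 log units; within the scatter). Compound 4 `O=C(NCc1nnc(SCCCN2CCN(c3nc4ccccc4s3)CC2)o1)c1ccccc1` has benzamidomethyl in place of phenyl on an aromatic carbon of the five-membered ring: benzamidomethyl in place of phenyl on an aromatic carbon. Within the data shown here, no measured compound changes this group itself, so the evidence is only indirect. Two steps come closest, both on losing a group from the phenyl of compound 1 or compound 2: a 4.8-fold higher number from compound 1 to compound 3 (0.68 log units; beyond the scatter) and a 3.6-fold higher number from compound 2 to compound 3 (0.56 log units; beyond the scatter). Both are modest, and both show compound 3, with its bare phenyl, giving the higher number. Compound 4 also carries more than a bare phenyl, so a modest move to a lower number in this assay is expected, though with little certainty. The expected step is a 2.3-fold lower number from compound 3 to compound 4 (0.37 log units; beyond the scatter). For compound 4 the estimated value is 110000 nM, with an expected range of 35000 nM to 300000 nM.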

Compound 4, half-maximal inhibitory concentration: 88700 nM
The estimate for compound 4 lay 1.2-fold (0.09 log units) above the measured number; low and high end bracket the measured number.
By their numbers in this assay, from the lowest: compounds 1, 2 and 4 (each within the scatter of the next); then compound 3.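

Compound 4 shows that the group on this ring carbon need not be a phenyl bearing a substituent for the number to drop from that of compound 3: benzamidomethyl, with its amide, gives a 2.9-fold lower number from compound 3 to compound 4 (0.46 log units; beyond the scatter) in this assay as a modest step. Compared with the substituted phenyls, it cannot be told apart, with a 1.2-fold higher number from compound 2 to compound 4 (0.09 log units; within the scatter) and a 1.6-fold higher number from compound 1 to compound 4 (0.22 log units; within the scatter) both within the scatter, so three quite different groups at this place give similar numbers, while the bare phenyl of compound 3 stands apart. No measurement here offers a reason for these steps.

On these data alone, it remains open which part of benzamidomethyl matters, the amide or its phenyl ring. Also untested in the compounds shown is how an amine, a carboxylic acid or a longer chain in place of the methylene would behave at this position.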